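The source may hold more compounds than are shown below. What is called first, only, known or untested is meant among the compounds shown, and "the series" means these compounds.

Among the compounds with values here, compound 2 `O=C(O)CCC(=O)N1N=C(c2c(-c3ccc(Br)cc3)c3ccccc3[nH]c2=O)CC1c1ccc(Cl)cc1` has the lowest number of the three compounds measured so far in an assay on cells (Oocyte) for negative allosteric modulation of glutamate receptor ionotropic, NMDA 2D (Rattus norvegicus), read by two-electrode voltage clamp; on this read-out lower numbers stand for stronger inhibition and higher numbers for weaker inhibition: in this assay compound 2 gives 290 nM. Compound 1 `O=C(O)CCC(=O)N1N=C(c2c(-c3ccccc3)c3cc(Cl)ccc3[nH]c2=O)CC1c1ccc(Br)cc1` is the nearest to it, and in this assay compound 1 gives 3100 nM, a weaker inhibition that lies beyond the usual scatter. Compound 3 `O=C(O)CCC(=O)N1N=C(c2c(-c3ccc(Cl)cc3)c3ccccc3[nH]c2=O)CC1c1ccccc1` is the furthest away, and in this assay compound 3 gives 11000 nM, again beyond the scatter. Compound 2 therefore stands as the most potent of the measured set.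

Compound 4 `O=C(O)CCC(=O)N1N=C(c2c(-c3cccc(C(F)(F)F)c3)c3ccccc3[nH]c2=O)CC1c1ccc(Cl)cc1` has not been measured. It differs from compound 2 in one place: 3-(trifluoromethyl)phenyl in place of 4-bromophenyl on an aromatic carbon. Within the data shown here, the other measured compounds carry yet other groups on that same carbon, but each of them also differs from compound 2 elsewhere, so no single measured step isolates this change and its effect can only be guessed. Exchanging a 4-bromophenyl for a 3-(trifluoromethyl)phenyl is a real change in shape and size of the group, and on the evidence available a loss of some potency seems more likely than a gain.

For compound 4 the estimate in this assay is 1000 nM, with a range from 250 nM to 4000 nM, which means an expected step of a 3.4-fold higher number from compound 2 to compound 4 (0.54 log units; beyond the scatter).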

Compound 4, half-maximal inhibitory concentration: 2600 nM
Estimate against measurement, compound 4: 2.6-fold (0.41 log units) below, and the stated range covers the measured number.
By their numbers in this assay, from the lowest: compound 2; then compounds 4 and 1 (each within the scatter of the next); then compound 3.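

In this assay, within the data shown here, replacing 4-bromophenyl with 3-(trifluoromethyl)phenyl on the aromatic carbon opposite the ring nitrogen gives a 9.0-fold higher number from compound 2 to compound 4 (0.95 log units; beyond the scatter), and this is the first comparison in which nothing else in the molecule changes. It shows that this position is sensitive to what the attached phenyl ring carries, since this single exchange costs clear potency, though the change combines a different group on the phenyl ring with a different place on it. The data offer no measurement that would explain the loss.

The step therefore cannot say whether the loss follows from giving up the bromine, from bringing in the trifluoromethyl group, or from moving the group from the 4-position to the 3-position. A 3-bromophenyl or a 4-(trifluoromethyl)phenyl group on the same carbon, each compared with compound 2 and compound 4, would separate these possibilities, while a 4-methoxyphenyl group would show how a group other than a halogen or trifluoromethyl fares at the 4-position.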